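A few compounds are considered here, and "the series" means these few. Any claim that something is new, unique, unknown or untested is made for them only; others in the source may bear on it.

The study measures growth inhibition of DU-145 cells in a functional assay on DU-145 cells (Homo sapiens) for inhibition, read by trypan blue exclusion, with a stated time of 96 h; a lower number here means a stronger inhibitor of growth, a higher number a weaker inhibitor of growth. Of the compounds shown here, three have numbers so far. Compound 1 `COc1ccc(/C=C(/SCc2ccc(F)cc2)C(=O)c2ccc(Br)cc2)cc1O` gives 1000 nM. Compound 2 `O=C(/C(=C\c1ccc(Cl)c([N+](=O)[O-])c1)S(=O)(=O)c1ccc(Br)cc1)c1ccc(Br)cc1` gives 10000 nM. Compound 3 `CSc1ccc(/C=C(\C(=O)c2ccc(Br)cc2)S(=O)(=O)Cc2ccc(C)cc2)cc1` gives 10000 nM.

On these numbers compound 2 and compound 3 are level at the digits shown, within the scatter of each other, and together they hold the highest numbers of the three. Within the data shown here, compound 1 stands furthest from compound 2, with a lower number that lies beyond the scatter; no direct single-point step connects compound 1 to compound 2, so only the two values themselves are known.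

Compound 4 `COc1ccc(/C=C(\C(=O)c2ccc(Br)cc2)S(=O)(=O)c2ccc(Br)cc2)cc1` has not been measured in this assay. It differs from compound 2 in one place: 4-methoxyphenyl in place of 4-chloro-3-nitrophenyl on a double-bonded chain carbon bound to a double-bonded chain carbon. Among the measured compounds shown here, no pair of measured compounds shows this same change, so the size of the step has to be judged from the spread of the three numbers alone. The author expects a modest step toward a lower number, of about a 2.0-fold lower number from compound 2 to compound 4 (0.30 log units; within the scatter), which may or may not clear the scatter. For compound 4 the expected result in this assay is 5000 nM, with a range from 1500 nM to 20000 nM.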

Compound 4, concentration for 50% growth inhibition: 25000 nM
For compound 4 the middle estimate is 5.0-fold (0.70 log units) below the measured one; measured number above the stated range.
By their numbers in this assay, from the lowest: compound 1; then compounds 2 and 3 (each within the scatter of the next); then compound 4.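

Among these compounds, compound 4 gives the first direct reading of the group on a double-bonded chain carbon bound to a double-bonded chain carbon, with everything else in the molecule held fixed. In this assay, 4-methoxyphenyl in place of 4-chloro-3-nitrophenyl brings a 2.5-fold higher number from compound 2 to compound 4 (0.40 log units; beyond the scatter), so on this background the group at this place does change the growth-inhibition read-out, and the change runs toward weaker inhibition, modestly but clearly. No data shown explain why the number moves in this direction.

This single pair cannot show whether the same replacement would move the number the same way with a different group on the sulfonyl, or whether the step comes from the chlorine, the nitro group or the methoxy group taken singly. It also leaves open how an amine or a carboxylic acid on this aromatic ring would read in this assay, and whether any group at this place can bring the number below that of compound 2.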